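The source may hold more compounds than are shown below. What is called first, only, known or untested is meant among the compounds shown, and "the series" means these compounds.

Working notes on the series.

Compound 1 `COc1cc(-c2cc(/C=C/C(=O)c3ccc(N)cc3)[nH]n2)cc(OC)c1OC` and compound 2 `COc1ccc(-c2cc(/C=C/C(=O)c3ccc(N)cc3)[nH]n2)cc1OC` differ in one place: hydrogen in place of methoxy on an aromatic carbon In a functional assay on NCI/ADR-RES cells (Homo sapiens) for cytotoxicity, read by sulforhodamine B assay, with a stated time of 48 h, tested at 0.1 uM (a lower number here means a stronger effect, a higher number a weaker effect of the compound at the concentration tested), compound 1 gives 110% and compound 2 gives 104%. The step of a number 6 percentage points lower from compound 1 to compound 2 (within the scatter) is therefore flat; at this concentration neither compound shows an effect in this assay.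

Compound 3 `COc1cc(C(=O)/C=C/c2cc(-c3cc(OC)c(OC)c(OC)c3)n[nH]2)cc(OC)c1OC` stands on a different core; the difference between the two cores is not broken down here. In this assay compound 3 gives 106%, which lies within the scatter of both compound 1 and compound 2. All three measured values sit at or near the level of untreated cells.

Compound 4 `COc1ccc(-c2cc(/C=C/C(=O)c3cc(OC)c(OC)c(OC)c3)[nH]n2)cc1OC` is compound 3 with the same change that turns compound 1 into compound 2: hydrogen in place of methoxy on an aromatic carbon The place of the change is the same in both pairs. Within the data shown here, the single precedent, a number 6 percentage points lower from compound 1 to compound 2 (within the scatter), gave no movement, and compound 3 itself is without effect in this assay, so the step of a number 2 percentage points lower from compound 3 to compound 4 (within the scatter) is expected to be flat as well. Compound 4 is estimated at 104% in this assay, with a range from 92% to 116%.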

Compound 4, a percentage reported as activity, at one concentration (the size of the read-out at that concentration, not a potency): 97%
Estimate against measurement, compound 4: 7 percentage points above; the measured number falls inside the stated range.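

Hydrogen in place of methoxy on an aromatic carbon gives a number 9 percentage points lower from compound 3 to compound 4 (within the scatter) in this assay and the step reads as flat. Set beside the earlier step, the change behaves alike on the two cores: the same change on two cores in this assay, a number 6 percentage points lower (within the scatter) from compound 1 to compound 2 and a number 9 percentage points lower (within the scatter) from compound 3 to compound 4, 3 percentage points apart, within the scatter of two such steps

Among these compounds, this agreement rests on only two pairs, and all four compounds sit at or near the level of untreated cells at the single concentration tested, so it shows two flat steps and no more. It does not show that the change would carry over in the same way to a compound with a clear effect, nor does it say anything about potency.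

Going by these compounds, whether any compound of this series has a clear effect in this assay remains open, as does whether the two cores would still agree under such conditions. Also open, on these data alone, is what a hydroxyl group, a chlorine atom or a carboxylic acid would do on the same aromatic carbon in place of the methoxy group.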